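Expected effect of trifluoromethyl in place of fluoro

A few compounds are considered here, and "the series" means these few. Any claim that something is new, unique, unknown or untested is made for them only; others in the source may bear on it.

Compound 1 `CCCc1nc(-c2ccccc2)c(CNCCN2CCN(c3ccc(Cl)cc3)CC2)o1`: 2820 nM
Compound 2 `CCCc1nc(-c2ccccc2)c(CNCCCN2CCN(c3ccc(F)cc3)CC2)o1`: 3210 nM
Compound 3 `CCCc1nc(-c2ccccc2)c(CNCCN2CCN(c3ccc(F)cc3)CC2)o1`: 7080 nM

These three compounds share one core and differ only in the group on the terminal aromatic ring and in the length of the linking chain. In an assay on HEK293 cells for inhibition of Voltage-dependent T-type calcium channel subunit alpha-1G (Homo sapiens), read by patch clamp (a lower number here means a stronger inhibitor, a higher number a weaker inhibitor), compound 2 gives 3210 nM, the second highest of the three numbers; its nearest neighbour is compound 1 with 2820 nM, a gap within the scatter, while compound 3 with 7080 nM lies beyond the scatter above it.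

Compound 4 `CCCc1nc(-c2ccccc2)c(CNCCCN2CCN(c3ccc(C(F)(F)F)cc3)CC2)o1` has not yet been measured. It differs from compound 2 by trifluoromethyl in place of fluoro on an aromatic carbon. Among the compounds with values here, the only measured step that touches the same aromatic carbon is a 2.5-fold higher number from compound 1 to compound 3 (0.40 log units; beyond the scatter), in which fluoro in place of chloro gave a weaker inhibitor. Within the data shown here, no measured pair shows the change from fluoro to trifluoromethyl itself, so the expectation rests on that one step by analogy: moving away from fluoro is expected to bring a modest step toward a lower number in this assay, of roughly the same size as the step from compound 1 to compound 3 but in the opposite direction. Compound 4 is therefore estimated to give 1600 nM in this assay, within 600 nM to 4500 nM, meaning an expected step of a 2.0-fold lower number from compound 2 to compound 4 (0.30 log units; within the scatter).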

Compound 4, half-maximal inhibitory concentration: 7250 nM
Compound 4: the middle estimate sits 4.5-fold (0.66 log units) below what was measured, and the stated range ends below it.
By their numbers in this assay, from the lowest: compounds 1 and 2 (each within the scatter of the next); then compounds 3 and 4 (each within the scatter of the next).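

In this assay, the step of a 2.3-fold higher number from compound 2 to compound 4 (0.35 log units; beyond the scatter) shows that on the longer linking chain, replacing fluoro with trifluoromethyl on this aromatic carbon gives a weaker inhibitor, so moving away from fluoro does not by itself bring a lower number. The earlier step of a 2.5-fold higher number from compound 1 to compound 3 (0.40 log units; beyond the scatter), on the shorter chain, showed only that chloro gives a lower number than fluoro there; taken together, the two steps show that the outcome at this carbon depends on which group enters, and they give no single order for all three groups, as they were read on different chains. None of the information at hand bears on why the number rises with trifluoromethyl at this carbon.

The compounds shown leave open how chloro behaves on the longer chain and how trifluoromethyl behaves on the shorter one, and thus whether the effects of these groups carry over from one chain length to the other. Also open, on these data alone, is how a nitrile, a methoxy group or a plain hydrogen at this carbon would read in this assay.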